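Lengthening one methoxy group on compound 3

The source may report more compounds than this note shows. Statements on the series, on what has been measured and on what is new or still open speak of the compounds shown alone.

Compound 3 `COc1cc(OC)c(/C=C/S(=O)(=O)Nc2ccc(OC)c([N+](=O)[O-])c2)c(OC)c1` sits in the middle of three compounds tested in a functional assay on K562 cells (Homo sapiens) for cytotoxicity, read by trypan blue exclusion, with a stated time of 96 h; on this read-out higher numbers stand for weaker inhibition and lower numbers for stronger inhibition. There compound 3 gives 1000 nM, while compound 1 `COc1cc(OC)c(/C=C/S(=O)(=O)Nc2cc([N+](=O)[O-])c(OC)c([N+](=O)[O-])c2)c(OC)c1` gives 10000 nM and compound 2 `COc1cc(OC)c(/C=C/S(=O)(=O)Nc2ccc(OC)c(O)c2)c(OC)c1` gives 15 nM.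

Compound 4 `COc1ccc(NS(=O)(=O)/C=C/c2c(OC)cc(OCCCC(=O)O)cc2OC)cc1[N+](=O)[O-]` keeps the structure of compound 3 apart from one change: 2-carboxyethyl in place of hydrogen on a saturated chain carbon bound to an oxygen on an aromatic ring. This turns a methoxy into a 3-carboxypropoxy. The two measured steps are a 10-fold lower number from compound 1 to compound 3 (1.00 log units; beyond the scatter) and a 67-fold higher number from compound 2 to compound 3 (1.82 log units; beyond the scatter). Both swap groups at a different place in the molecule, so neither speaks directly to this change. For the measured compounds named here, they show only that a single swap can move this number a long way. Going by the values given here, no tested compound carries a longer chain at this oxygen, so the direction is a cautious judgement and not a measured trend.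

The expected change is a 3.0-fold higher number from compound 3 to compound 4 (0.48 log units; beyond the scatter) in this assay, a modest move toward weaker inhibition. For compound 4 the estimated value is 3000 nM, with an expected range of 500 nM to 15000 nM.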

Compound 4, half-maximal inhibitory concentration: 100000 nM
For compound 4 the middle estimate is 33-fold (1.52 log units) below the measured one; the whole stated range lies below it.
By their numbers in this assay, from the lowest: compound 2; then compound 3; then compound 1; then compound 4.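

In this assay, replacing the methoxy of compound 3 with 3-carboxypropoxy gives a large loss of inhibition (a 100-fold higher number from compound 3 to compound 4 (2.00 log units; beyond the scatter)). The earlier steps shown here showed that swaps elsewhere on the molecule can move this number a long way, and this step shows that the oxygen carrying this methoxy is just as sensitive to change. Nothing measured here explains why the number climbs so far.

This one change both lengthens the chain and adds a carboxylic acid, so the compounds shown cannot separate the two effects. Going by these compounds, a plain butoxy group, with a similar chain and no acid, or a chain ending in an amine, would help show which part of the change matters, and whether a shorter chain is tolerated remains open too.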